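A Second Chlorine on the Phenyl of a Triazole Series

A few compounds are considered here, and "the series" means these few. Any claim that something is new, unique, unknown or untested is made for them only; others in the source may bear on it.

Compound 1 `N#CC1=C(N)Oc2c(c3nc4ccccc4nc3c3ccccc23)C12C(=O)N(Cc1cnnn1-c1ccc(Cl)cc1)c1ccccc12` was tested in a functional assay on A549 cells (Homo sapiens) for antiproliferative activity, read by MTT assay, with a stated time of 48 h; a higher number here means a weaker inhibitor, a lower number a stronger inhibitor. In this assay compound 1 gives > 50000 nM, which is a limit of the assay rather than a number, as the limit of > 50000 nM in this assay, at which 1 of the 2 values shown sits, records. Compound 2 `CCOc1ccc(-n2nncc2CN2C(=O)C3(C(C#N)=C(N)Oc4c3c3nc5ccccc5nc3c3ccccc43)c3ccccc32)cc1` gives 25200 nM in this assay. Going by the values given here, the only measured step, an at least 1.9-fold lower number from compound 1 to compound 2 (0.29 log units; that floor lies within the scatter), concerns a different change and so does not bear directly on the change leading to compound 3 `N#CC1=C(N)Oc2c(c3nc4ccccc4nc3c3ccccc23)C12C(=O)N(Cc1cnnn1-c1cc(Cl)ccc1Cl)c1ccccc12`: 2,5-dichlorophenyl in place of 4-chlorophenyl on an aromatic nitrogen. Among the compounds with values here, with no measured step speaking to this change, no shift beyond the scatter is expected. Compound 3 is therefore estimated at 45000 nM, within 15000 nM to 150000 nM. The expected step is an at least 1.1-fold lower number from compound 1 to compound 3 (0.04 log units; that floor lies within the scatter).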

Compound 3, half-maximal inhibitory concentration: > 50000 nM
Compound 3 ended at the assay's limit (the forecaster's own chance of this, stated with the estimate: 60%); middle value at least 1.1-fold (0.04 log units) away from the limit.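

Compound 3 joins compound 1 at a limit of the assay: the limit of > 50000 nM in this assay, at which 2 of the 3 values shown sit. The 2,5-dichlorophenyl group in place of 4-chlorophenyl thus brings no value off that limit, and the step between these two compounds cannot be read. Set against 4-ethoxyphenyl, the same group gives an at least 1.9-fold higher number from compound 2 to compound 3 (0.29 log units; that floor lies within the scatter), so this comparison shows no difference beyond the scatter either.

From the compounds shown here alone, what remains open is how far the shared core can move from the limit in this assay with other groups on this phenyl, such as an amine or a carboxylic acid.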